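Hydroxamic acid chain length on two bicyclic cores

The source may hold more compounds than are shown below. What is called first, only, known or untested is meant among the compounds shown, and "the series" means these compounds.

Compounds measured so far in a functional assay on A549 cells (Homo sapiens) for inhibition, read by MTT assay, with a stated time of 72 h; on this read-out higher numbers stand for weaker inhibition and lower numbers for stronger inhibition:
- compound 1, `Nc1ncnc2c1c(-c1cnc3[nH]ccc3c1)nn2CC(=O)NO`, gives a limit of the assay, > 150000 nM.
- compound 2, `Nc1ncnc2c1c(-c1cnc3[nH]ccc3c1)nn2CCCCCC(=O)NO`, gives a limit of the assay, > 150000 nM.
- compound 3, `Nc1nc2cc(-c3nn(CCCCCC(=O)NO)c4ncnc(N)c34)ccc2o1`, gives a limit of the assay, > 100000 nM.

None of the three values is a number; each is a limit. Two of them sit at the limit of > 150000 nM in this assay, at which 2 of the 3 values shown sit, and one at the limit of > 100000 nM in this assay, at which 1 of the 3 values shown sits. Between compound 2 and compound 1 the change is hydroxycarbamoyl in place of 4-(hydroxycarbamoyl)butyl on a saturated chain carbon bound to an aromatic nitrogen, and the step that the two limits leave unreadable from compound 2 to compound 1 cannot be read, since both ends are limits.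

Compound 3 carries a different core from compound 2; the difference between the two cores is not broken down here. Compound 4, `Nc1nc2cc(-c3nn(CC(=O)NO)c4ncnc(N)c34)ccc2o1`, stands to compound 3 as compound 1 stands to compound 2: the change is hydroxycarbamoyl in place of 4-(hydroxycarbamoyl)butyl on a saturated chain carbon bound to an aromatic nitrogen, the same change as before, at the same place.

For compound 4 in this assay , the step that the limit leaves unreadable from compound 3 to compound 4 is expected to be small and to stay unreadable, because compound 3 gives only a limit, > 100000 nM, and compound 1 gives only a limit, > 150000 nM. Compound 4 is therefore estimated at 150000 nM, with a range from 50000 nM to 500000 nM, and most likely the assay will again report only a limit.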

Compound 4, half-maximal inhibitory concentration: 27700 nM
Beside the measured number, compound 4's estimate is 5.4-fold (0.73 log units) above it, and the stated range ends above it.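

For the compounds shown here, on the core of compound 3, replacing 4-(hydroxycarbamoyl)butyl with hydroxycarbamoyl on a saturated chain carbon bound to an aromatic nitrogen gives, in this assay, an at least 3.6-fold lower number from compound 3 to compound 4 (0.55 log units; beyond the scatter), and compound 4 gives 27700 nM, the only number among the four compounds. On the core of compound 1 the same change cannot be read, so the series shows the change lowering the number on one core only and does not show whether it carries over to the other: both compounds on that core are limits of the assay: the limit of > 150000 nM in this assay, at which 2 of the 4 values shown sit. The step on the core of compound 3 also gives only a minimum for the size of the change, not its full size, as compound 3 is a limit of the assay: the limit of > 100000 nM in this assay, at which 1 of the 4 values shown sits.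

The compounds shown leave open how the number moves with chains of other lengths on either core, for instance 2-(hydroxycarbamoyl)ethyl, which would fall between the two chains compared here. They also leave open whether the hydroxycarbamoyl group itself is needed for the number of compound 4, which a carboxylic acid or a primary amide in its place on the same core would test.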